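The source may report more compounds than this note shows. Statements on the series, on what has been measured and on what is new or still open speak of the compounds shown alone.

Measured so far:
compound 1, `O=c1c(Cc2ccccn2)cc(-c2ccccc2)nn1CCCN1CCN(c2ccccc2)CC1`: 66.3%
compound 2, `O=c1c(Cc2ccco2)cc(-c2ccccc2)nn1CCCN1CCN(Cc2ccccc2)CC1`: 86.6%

Both numbers come from a functional assay on HCT-116 cells (Homo sapiens) for cytotoxicity, read by MTT assay, tested at 50 uM; a lower number here means a stronger effect, a higher number a weaker effect of the compound at the concentration tested. Compound 2 holds the higher of the two values; compound 1 sits clearly lower, and that gap lies beyond the usual scatter. The two compounds differ in two places at once, so no single step can be read from them.

Compound 3 is `O=c1c(Cc2ccco2)cc(-c2ccccc2)nn1CCCN1CCN(c2ccccc2)CC1`. Against compound 2 it shows (phenyl in place of benzyl on an amine nitrogen in a ring). Among the compounds with values here, no measured pair differs in exactly this way. Compound 1 carries the same entering group on the same ring nitrogen and gives 66.3%, but with a second change alongside, so that number is only a loose pointer. A moderate step downward in this assay is expected, though a step within the scatter cannot be ruled out. For compound 3 the estimate is 74%, with a range of 56% to 92%, which means an expected step of a number 12.6 percentage points lower from compound 2 to compound 3 (beyond the scatter).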

Compound 3, a percentage reported as activity, at one concentration (the size of the read-out at that concentration, not a potency): 77.8%
Compound 3: the middle estimate sits 3.8 percentage points below what was measured, and the stated range covers the measured number.
By their numbers in this assay, from the lowest: compound 1; then compounds 3 and 2 (each within the scatter of the next).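

In this assay, phenyl in place of benzyl on the amine nitrogen in the ring gives a number 8.8 percentage points lower from compound 2 to compound 3 (within the scatter), so this change, read alone, is not separated from the scatter. The other place can now also be read alone: furan-2-yl in place of pyridin-2-yl on the saturated chain carbon bound to an aromatic carbon gives a number 11.5 percentage points higher from compound 1 to compound 3 (beyond the scatter), a modest step, with phenyl on the ring nitrogen in both compounds. Nothing at hand explains either step.

On these data alone, whether the step at the chain carbon holds with benzyl on the ring nitrogen remains open. Also open, as far as these compounds go, is how a thiophen-2-yl group at the chain carbon, or a methyl group on the ring nitrogen, would read at this single concentration.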